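Chloro step repeated on the longer-chain analogue

The source may report more compounds than this note shows. Statements on the series, on what has been measured and on what is new or still open speak of the compounds shown alone.

Compound 1 `CCCCCCC(CCO)n1cnc2c(N)ncnc21` and compound 2 `CCCCCCC(CCO)n1cnc2c(N)nc(Cl)nc21` differ by chloro in place of hydrogen on an aromatic carbon. In a functional assay on HCT-116 cells (Homo sapiens) for antiproliferative activity, read by MTT assay, with a stated time of 48 h (on this read-out lower numbers stand for stronger inhibition and higher numbers for weaker inhibition), compound 1 gives only a limit, > 50000 nM. Compound 2 likewise gives only a limit in this assay, > 50000 nM. The step that the two limits leave unreadable from compound 1 to compound 2 is therefore unreadable, both values sitting at the limit of > 50000 nM in this assay, at which 2 of the 3 values shown sit. Compound 3 `CCCCCCCCCCCC(CCO)n1cnc2c(N)ncnc21` differs from compound 1 by pentyl in place of hydrogen on a saturated chain carbon, seven bonds along the chain from an aromatic nitrogen; in this assay compound 3 gives 13400 nM, the step being an at least 3.7-fold lower number from compound 1 to compound 3 (0.57 log units; beyond the scatter). Compound 4 `CCCCCCCCCCCC(CCO)n1cnc2c(N)nc(Cl)nc21` carries relative to compound 3 the change (chloro in place of hydrogen on an aromatic carbon), the same change as from compound 1 to compound 2. That earlier pairing left no readable size, so no direction can be taken from it; the step from compound 3 to compound 4 is expected to be small, a 1.2-fold lower number from compound 3 to compound 4 (0.09 log units; within the scatter), resting on compound 3 at 13400 nM. Compound 4 is estimated at 11000 nM, between 3000 nM and 40000 nM.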

Compound 4, half-maximal inhibitory concentration: 20000 nM
Beside the measured number, compound 4's estimate is 1.8-fold (0.26 log units) below it; measured number inside the range.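

In this assay, chloro in place of hydrogen on the longer-chain core gives a 1.5-fold higher number from compound 3 to compound 4 (0.17 log units; within the scatter), and on the shorter-chain core the same change cannot be read: the limit of > 50000 nM in this assay, at which 2 of the 4 values shown sit. The pentyl change, read on the chloro core, gives an at least 2.5-fold lower number from compound 2 to compound 4 (0.39 log units; beyond the scatter), pointing the same way on both cores: the same change on two cores in this assay, an at least 3.7-fold lower number (0.57 log units; beyond the scatter) from compound 1 to compound 3 and an at least 2.5-fold lower number (0.39 log units; beyond the scatter) from compound 2 to compound 4; the limit leaves it open whether they differ The chloro change therefore has no readable size to carry from one core to the other, and the pentyl change is shown to carry in direction only, not in size.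

Going by these compounds, whether bromo or an amine at that same place would behave differently from chloro remains open. So does whether a chain longer than that of compound 3 would lower the number further.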